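This account rests on a few compounds, and the source may have more. Where it says the series, first, only, none or still open, it means among the compounds named here.

- compound 1 `N=C(N)c1ccc(-c2ccc(-c3ccc(C(=N)N)cc3)c(F)c2)cc1` gives 6400 nM
- compound 2 `N=C(N)c1ccc(-c2ccc(-c3ccc(C(=N)N)o3)cc2)cc1` gives 56100 nM
- compound 3 `CONC(=N)c1ccc(-c2ccc(-c3ccc(C(=N)NOC)cc3)c(F)c2)cc1` gives 8500 nM

In a functional assay on L6 cells (Rattus norvegicus) for cytotoxicity (on this read-out higher numbers stand for weaker inhibition and lower numbers for stronger inhibition), compound 3 reads 8500 nM on the scale. That number lies within the scatter of compound 1 at 6400 nM. The gap to compound 2 is beyond the scatter, with compound 3 well under compound 2 at 56100 nM on the same scale.

Compound 4 `CONC(=N)c1ccc(-c2ccc(-c3ccc(C(=N)NOC)cc3)c(C(F)(F)F)c2)cc1` keeps the structure of compound 3 except for one group: trifluoromethyl in place of fluoro on an aromatic carbon, ortho to a large group and meta to a large group. The count for this swap reads trifluoromethyl in place of fluoro on an aromatic carbon and nothing else changes.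

Among the compounds with values here, no measured pair shows this swap, so the numbers offer no direct guide, and compound 3 at 8500 nM is the only starting point. In this assay the expected outcome is a 1.2-fold lower number from compound 3 to compound 4 (0.08 log units; within the scatter) as a small shift, none beyond the scatter. For compound 4 the estimated value is 7000 nM with an expected range from 2000 nM to 25000 nM as its honest width.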

Compound 4, half-maximal inhibitory concentration: 42200 nM
Estimate against measurement, compound 4: 6.0-fold (0.78 log units) below; the whole stated range lies below it.
By their numbers in this assay, from the lowest: compounds 1 and 3 (each within the scatter of the next); then compounds 4 and 2 (each within the scatter of the next).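

In this assay, trifluoromethyl in place of fluoro on an aromatic carbon, ortho to a large group and meta to a large group, gives a 5.0-fold higher number from compound 3 to compound 4 (0.70 log units; beyond the scatter). This is the first change in one place only among the compounds shown, and it reveals that the read-out is sensitive to which group sits at this position. The shift runs towards weaker inhibition of the cells, and no measurement at hand says why it happens.

On these data alone, it remains open whether a methyl group or a chlorine atom at the same position would read like fluoro or like trifluoromethyl. As far as these compounds go, it is also open whether the same swap would move the number in the same direction on compound 1, whose two end groups differ from those of compound 3.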